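This account rests on a few compounds, and the source may have more. Where it says the series, first, only, none or still open, it means among the compounds named here.

Compound 1 `CCc1nc(Cl)ncc1C(=O)Nc1cc(C(F)(F)F)cc(C(F)(F)F)c1`: 400 nM
Compound 2 `O=C(Nc1cc(C(F)(F)F)cc(C(F)(F)F)c1)c1cnc(Cl)nc1-c1cccs1`: 9800 nM
Compound 3 `O=C(Nc1cc(C(F)(F)F)cc(C(F)(F)F)c1)c1cnc(Cl)nc1-c1ccccc1`: 400 nM

In an assay on Jurkat cells for activation of nuclear factor NF-kappa-B complex (Homo sapiens) (on this read-out higher numbers stand for weaker inhibition and lower numbers for stronger inhibition), compound 3 gives 400 nM, and together with compound 1 it holds the lowest number of the three: no change at the digits printed from compound 1 to compound 3 (within the scatter), whereas a 25-fold lower number from compound 2 to compound 3 (1.39 log units; beyond the scatter). Compound 4 `Cc1nc(Cl)ncc1C(=O)Nc1cc(C(F)(F)F)cc(C(F)(F)F)c1` follows from compound 3 by a single change: methyl in place of phenyl on an aromatic carbon. Among the measured compounds shown here, two measured steps bear on this. The step of no change at the digits printed from compound 1 to compound 3 (within the scatter) shows that ethyl and phenyl at this position give the same number, and methyl is a shorter chain of the same kind as ethyl. The step of a 25-fold lower number from compound 2 to compound 3 (1.39 log units; beyond the scatter) shows that this position can move the number a long way, but only thiophen-2-yl has done so. For the measured compounds named here, no measured step trades phenyl for methyl directly, so the expectation rests on the ethyl case. On that basis the step of a 1.3-fold higher number from compound 3 to compound 4 (0.10 log units; within the scatter) is expected to stay within the scatter, with at most a small rise. Compound 4 is therefore estimated at 500 nM in this assay, with a range from 200 nM to 1500 nM.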

Compound 4, half-maximal inhibitory concentration: 50 nM
The estimate for compound 4 lay 10-fold (1.00 log units) above the measured number, and the stated range ends above it.
By their numbers in this assay, from the lowest: compound 4; then compounds 1 and 3 (each within the scatter of the next); then compound 2.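

In this assay, shortening ethyl to methyl gives an 8.0-fold lower number from compound 1 to compound 4 (0.90 log units; beyond the scatter), so this position responds to a change between two small alkyl groups, even though ethyl and phenyl had stood level. Methyl in place of the aromatic groups gives an 8.0-fold lower number from compound 3 to compound 4 (0.90 log units; beyond the scatter) and a 200-fold lower number from compound 2 to compound 4 (2.29 log units; beyond the scatter), which places compound 4 lowest of the four. Group size alone does not order the series, since compound 3 with its phenyl stands level with compound 1 with its ethyl, and compound 2 with its thiophen-2-yl has the highest number; nothing available explains why the methyl compound stands apart.

Still open, from the compounds shown here alone, is how hydrogen, a methoxy group or an amine on this aromatic carbon would compare with methyl. So is whether the gain from methyl would persist with another group in place of the chloro group.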